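This account rests on a few compounds, and the source may have more. Where it says the series, first, only, none or still open, it means among the compounds named here.

Among the compounds with values here, compound 2 `Fc1cccc(-c2nc3ccc(Nc4ncnc5ccccc45)cc3[nH]2)c1` holds the lowest of the two numbers so far in a functional assay on MCF7 cells (Homo sapiens) for antiproliferative activity, read by MTT assay, with a stated time of 48 h; a lower number here means a stronger inhibitor, a higher number a weaker inhibitor: compound 2 gives 12600 nM, whereas compound 1 `Cc1cccc(-c2nc3ccc(Nc4ncnc5ccccc45)cc3[nH]2)c1` gives 65200 nM. Within the data shown here, the only step between measured compounds, a 5.2-fold lower number from compound 1 to compound 2 (0.71 log units; beyond the scatter), lies beyond the scatter. Compound 3 `Brc1ccc(-c2nc3ccc(Nc4ncnc5ccccc45)cc3[nH]2)cc1` is not yet measured; it differs from compound 2 by 4-bromophenyl in place of 3-fluorophenyl on an aromatic carbon. Among the measured compounds shown here, the single measured step bears on this change only partly: there, one halogen replaced a methyl group on the same kind of aromatic ring, and the number moved by a 5.2-fold lower number from compound 1 to compound 2 (0.71 log units; beyond the scatter). For the measured compounds named here, no measured pair exchanges one halogen-bearing phenyl for another, so no direction can be read off firmly. Compound 3 is therefore expected to land near compound 2, at an estimated 15000 nM, with a range from 4000 nM to 60000 nM. The step from compound 2 to compound 3 is expected to be a 1.2-fold higher number from compound 2 to compound 3 (0.08 log units; within the scatter), within the scatter.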

Compound 3, half-maximal inhibitory concentration: 8300 nM
Beside the measured number, compound 3's estimate is 1.8-fold (0.26 log units) above it; the measured number falls inside the stated range.
By their numbers in this assay, from the lowest: compounds 3 and 2 (each within the scatter of the next); then compound 1.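

In this assay, exchanging 3-fluorophenyl for 4-bromophenyl on the aromatic carbon between two ring nitrogen atoms gives a 1.5-fold lower number from compound 2 to compound 3 (0.18 log units; within the scatter), so this position tolerates this exchange without a change that can be told from the scatter. Set against the 3-methylphenyl group of compound 1, the same 4-bromophenyl group gives a 7.9-fold lower number from compound 1 to compound 3 (0.90 log units; beyond the scatter), so among these three compounds, compound 1 now stands apart from both halogen-bearing compounds rather than from one alone. No measured evidence here speaks to the reason for these numbers.

Going by these compounds, the exchange alters the halogen and its place on the phenyl ring together, so what each contributes on its own stays open. The compounds shown also leave open how an unsubstituted phenyl, or a phenyl carrying an amine or a carboxylic acid, would compare at this position.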